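Aryl Sulfonamides with a Cyclic Urea: Predicting a Dimethylphenyl Analogue

This account rests on a few compounds, and the source may have more. Where it says the series, first, only, none or still open, it means among the compounds named here.

Measured compounds:
Compound 1, `O=C1NCCN1c1ccc(S(=O)(=O)Nc2cccc(Br)c2)cc1`: 170 nM
Compound 2, `Cc1cc(C)cc(NS(=O)(=O)c2ccc(N3CCNC3=O)cc2)c1`: 150 nM
Compound 3, `O=C1NCCN1c1ccc(S(=O)(=O)Nc2cccc(Cl)c2)cc1`: 68 nM

The three compounds were tested in a functional assay on HT-1080 cells (Homo sapiens) for antiproliferative activity, read by sulforhodamine B assay, with a stated time of 48 h; a lower number here means a stronger inhibitor, a higher number a weaker inhibitor. Compound 3 gives the lowest number of the three in this assay, 68 nM; compound 2 is nearest with 150 nM, and compound 1 is furthest with 170 nM. The gaps are modest but beyond the scatter: a 2.2-fold lower number from compound 2 to compound 3 (0.34 log units; beyond the scatter) and a 2.5-fold lower number from compound 1 to compound 3 (0.40 log units; beyond the scatter), while a 1.1-fold lower number from compound 1 to compound 2 (0.05 log units; within the scatter).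

The next compound, compound 4, `Cc1ccc(C)c(NS(=O)(=O)c2ccc(N3CCNC3=O)cc2)c1`, differs from compound 3 in one place:
2,5-dimethylphenyl in place of 3-chlorophenyl on a sulfonamide nitrogen

Within the data shown here, the step that bears most on this change is the one between compound 2 and compound 3, where a 2.2-fold lower number from compound 2 to compound 3 (0.34 log units; beyond the scatter). Compound 4 reverses that exchange, returning from a chlorophenyl to a dimethylphenyl, though with the methyl groups on a different arrangement of the ring; the data hold no direct comparison between 2,5-dimethylphenyl and 3,5-dimethylphenyl. A modest rise in the number, back toward the value of compound 2, is therefore expected for compound 4, with the direction uncertain in size because a 2.2-fold lower number from compound 2 to compound 3 (0.34 log units; beyond the scatter) was itself only modest. The expected step is a 2.2-fold higher number from compound 3 to compound 4 (0.34 log units; beyond the scatter), giving an estimate for compound 4 of 150 nM, with a range from 60 nM to 400 nM.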

Compound 4, half-maximal inhibitory concentration: 65 nM
The estimate for compound 4 lay 2.3-fold (0.36 log units) above the measured number, and the stated range covers the measured number.
By their numbers in this assay, from the lowest: compounds 4 and 3 (each within the scatter of the next); then compounds 2 and 1 (each within the scatter of the next).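

In this assay, placing 2,5-dimethylphenyl on the sulfonamide nitrogen instead of 3-chlorophenyl gives a 1.0-fold lower number from compound 3 to compound 4 (0.02 log units; within the scatter) and so shows that this position can hold a dimethylphenyl group without departing from the number of the chlorophenyl compound. Among these compounds, the earlier compounds could not show this, as their only dimethylphenyl example was the 3,5-dimethylphenyl group; the exchange of that group for 2,5-dimethylphenyl gives a 2.3-fold lower number from compound 2 to compound 4 (0.36 log units; beyond the scatter) and shows that the arrangement of the two methyl groups on the ring matters in this assay, even though the ring carries the same substituents in both compounds. The exchange of 3-bromophenyl for 2,5-dimethylphenyl gives a 2.6-fold lower number from compound 1 to compound 4 (0.42 log units; beyond the scatter) in the same direction, but nothing available here explains any of these differences.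

The compounds shown leave open how other arrangements of two methyl groups, or a single methyl group, would compare at this position. They also leave open whether a ring bearing a methoxy group, an amine or a carboxylic acid would keep a number in the range of compound 3 and compound 4.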